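This account rests on a few compounds, and the source may have more. Where it says the series, first, only, none or still open, it means among the compounds named here.

Of the compounds shown here, three sharing one core have been tested in a functional assay on K562 cells (Homo sapiens) for cytotoxicity, read by MTT assay, with a stated time of 24 h; on this read-out lower numbers stand for stronger inhibition and higher numbers for weaker inhibition. Compound 1 `COc1ccc(/C=C2\CN(C)C/C(=C\c3ccccc3F)C2=O)cc1OC` gives 18000 nM. Compound 2 `COc1cc(/C=C2\CN(C)C/C(=C\c3ccc(Cl)cc3)C2=O)cc(OC)c1` gives 13300 nM. Compound 3 `COc1cc(/C=C2\CN(C)C/C(=C\c3ccc(Cl)cc3)C2=O)cc(OC)c1OC` gives no exact number, only a limit of the assay, > 20000 nM. This is the limit of > 20000 nM in this assay, at which 1 of the 3 values shown sits, so compound 3 can be placed only by that limit and not by a measured value.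

Compound 4 `COc1cc(/C=C2\CN(C)C/C(=C\c3ccc(C#N)cc3)C2=O)cc(OC)c1OC` keeps everything in compound 3 except one group on the 4-chlorophenyl: cyano in place of chloro on an aromatic carbon, (cyano in place of chloro on an aromatic carbon). Going by the values given here, no measured step makes this exchange, so the evidence is only indirect. Among the compounds with values here, the one step between measured compounds is a different change, methoxy in place of hydrogen on an aromatic carbon, and it shows an at least 1.5-fold higher number from compound 2 to compound 3 (0.17 log units; that floor lies within the scatter). The three values also lie close together despite their different substituents, although this rests on very few compounds.

In this assay, the expected result is therefore no clear move in either direction, with an estimated at least 1.3-fold lower number from compound 3 to compound 4 (0.12 log units; that floor lies within the scatter). For compound 4 the estimated value is 15000 nM, with an expected range from 7000 nM to 30000 nM.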

Compound 4, half-maximal inhibitory concentration: 4290 nM
The estimate for compound 4 lay 3.5-fold (0.54 log units) above the measured number, outside the stated range (below it).
By their numbers in this assay, from the lowest: compound 4; then compounds 2 and 1 (each within the scatter of the next). At a limit, above all of these: compound 3.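

Exchanging chloro for cyano on an aromatic carbon, para to a large group, produces the only step shown that lies beyond the scatter: in this assay there is an at least 4.6-fold lower number from compound 3 to compound 4 (0.66 log units; beyond the scatter). The earlier step, an at least 1.5-fold higher number from compound 2 to compound 3 (0.17 log units; that floor lies within the scatter), added a methoxy elsewhere in the molecule and stayed within the scatter, so this position on the 4-chlorophenyl is the one place where a single exchange is seen to move the number clearly. The size of this step is only a floor and the real gap may be larger, as compound 3 is placed by a limit alone: the limit of > 20000 nM in this assay, at which 1 of the 4 values shown sits.

One exchange at one position cannot tell whether the cyano matters in particular or whether other groups there, such as a nitro, a carboxylic acid or an amine, would lower the number as well. As far as these compounds go, it also remains open whether the same exchange would have a similar effect with the two methoxy groups of compound 2 on the other side of the shared core, and these values give no reason for the drop.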